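Shifting the pyridine nitrogen in a nicotinamide phosphoribosyltransferase inhibitor

A few compounds are considered here, and "the series" means these few. Any claim that something is new, unique, unknown or untested is made for them only; others in the source may bear on it.

Compound 1 `C#Cc1cccc(Nc2ncnc3cc(OC)c(OCCCCCCN/C(=N\C#N)Nc4cccnc4)cc23)c1` and compound 2 `C#Cc1cccc(Nc2ncnc3cc(OC)c(OCCCCCCCN/C(=N\C#N)Nc4cccnc4)cc23)c1` share the same core and differ only in the length of the chain that carries the cyanoguanidine. In an assay on isolated protein for inhibition of Nicotinamide phosphoribosyltransferase (Homo sapiens), read by colorimetric assay, with stated times of 60 min, 30 min and 5 min (a lower number here means a stronger inhibitor, a higher number a weaker inhibitor), compound 1 gives 133 nM, while compound 2 gives 152 nM, a gap that lies within the usual scatter, so the two cannot be told apart on these numbers.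

Compound 3 `C#Cc1cccc(Nc2ncnc3cc(OC)c(OCCCCCCN/C(=N\C#N)Nc4ccncc4)cc23)c1` keeps the six-carbon chain of compound 1 and changes only the aromatic ring on the far end: pyridin-4-yl in place of pyridin-3-yl on an amine nitrogen. Within the data shown here, no measured pair shows what this kind of move does here, so the expectation rests on the two measured compounds alone. The step from compound 1 to compound 3 is expected to be small, at most a modest weakening, and may lie within the scatter, as a 1.5-fold higher number from compound 1 to compound 3 (0.18 log units; within the scatter). Compound 3 is therefore estimated at 200 nM in this assay, with a range from 70 nM to 600 nM.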

Compound 3, half-maximal inhibitory concentration: 131 nM
For compound 3 the middle estimate is 1.5-fold (0.18 log units) above the measured one; the range from low to high includes it.
By their numbers in this assay, from the lowest: compounds 3, 1 and 2 (each within the scatter of the next).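

Putting pyridin-4-yl in place of pyridin-3-yl on the amine nitrogen gives a 1.0-fold lower number from compound 1 to compound 3 (0.01 log units; within the scatter) in this assay and so offers the first direct test of this position. The two rings have the same atoms joined differently, yet they cannot be told apart on these numbers, so on the chain of compound 1 this shift of the ring nitrogen produces no readable change in inhibition. No measurement shown here bears on why the two rings read alike.

The compounds shown leave open whether a pyridin-2-yl ring, or a phenyl ring with no ring nitrogen at all, would also read alike on this amine nitrogen. They also leave open whether the same swap would behave this way on the longer chain of compound 2.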